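A Hydroxy Swap on the Bare Core, Judged by Analogy

This account rests on a few compounds, and the source may have more. Where it says the series, first, only, none or still open, it means among the compounds named here.

Measured compounds:
Compound 1, `O=c1c(Cc2coc3cccc(OCC4CCCCC4)c3c2=O)coc2ccccc12`: in a functional assay on MDA-MB-231 cells (Homo sapiens) for antiproliferative activity, read by XTT assay (a lower number here means a stronger inhibitor, a higher number a weaker inhibitor), compound 1 gives 4110 nM.
Compound 2, `O=c1c(Cc2coc3cccc(OCC4CCCCC4)c3c2=O)coc2cc(O)ccc12`: compound 2 gives 3220 nM.
Compound 3, `O=c1c(Cc2coc3ccccc3c2=O)coc2ccccc12`: compound 3 reaches only a limit of the assay, > 10000 nM.

Compound 3 differs from compound 1 by hydrogen in place of cyclohexylmethoxy on an aromatic carbon. The step of an at least 2.4-fold higher number from compound 1 to compound 3 (0.38 log units; beyond the scatter), and since compound 3 stands at the limit of > 10000 nM in this assay, at which 1 of the 3 values shown sits, only a lower bound on that step is known. Compound 2 differs from compound 1 by hydroxy in place of hydrogen on an aromatic carbon, and the step of a 1.3-fold lower number from compound 1 to compound 2 (0.11 log units; within the scatter).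

Compound 4, `O=c1c(Cc2coc3cccc(O)c3c2=O)coc2ccccc12`, has not been measured. It differs from compound 3 by hydroxy in place of hydrogen on an aromatic carbon. Among the measured compounds shown here, this is the same kind of change as the one from compound 1 to compound 2, though not the same: in compound 2 the hydroxy sits meta to a fused ring and para to a fused ring, whereas in compound 4 it sits ortho to a fused ring and meta to a fused ring. Because the step of a 1.3-fold lower number from compound 1 to compound 2 (0.11 log units; within the scatter) stayed within the scatter, compound 4 is expected to remain close to compound 3, with an expected step that the limit leaves unreadable from compound 3 to compound 4. Compound 4 is thus estimated at 15000 nM, likely between 6000 nM and 40000 nM, and it may well return only a limit again.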

Compound 4, half-maximal inhibitory concentration: > 10000 nM
Compound 4: only a limit was reported (the forecaster's own chance of this, stated with the estimate: 60%); the middle value does not contradict the limit.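

In this assay compound 4 gives > 10000 nM, which is a limit of the assay and not a number. Compound 3 and compound 4 both stand at a limit, so the step between them cannot be read, and the hydroxy swap on the bare core cannot be set against a 1.3-fold lower number from compound 1 to compound 2 (0.11 log units; within the scatter); the result neither confirms nor refutes that the swap carries over from one core to the other: the limit of > 10000 nM in this assay, at which 2 of the 4 values shown sit.

The one readable result is an at least 2.4-fold higher number from compound 1 to compound 4 (0.38 log units; beyond the scatter), which shows that with hydrogen in place of cyclohexylmethyl on the oxygen, the hydroxy left on the ring does not bring compound 4 back to a measured value.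

The compounds shown leave open whether methyl, benzyl or a longer chain ending in an amine on that oxygen would return a value inside the range of the assay. They also leave open what a hydroxy does on the bare core when it stands at the place it holds in compound 2.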